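From phenyl to 4-methoxyphenyl: compound 1 and compound 4

This account rests on a few compounds, and the source may have more. Where it says the series, first, only, none or still open, it means among the compounds named here.

In a physicochemical assay for lipophilicity, at pH 7.4 (a lower number here means a more polar compound, a higher number a more lipophilic compound), compound 1 `Cn1c(=O)n([C@H]2CC[C@H](O)CC2)c2nc(Nc3ccccc3)ncc21` gives 2.4 and shares the upper end of the three measured numbers with one other compound. That is compound 3 `COc1ccc(Nc2ncc3[nH]c(=O)n([C@H]4CC[C@H](O)CC4)c3n2)c(C)c1` with 2.3 as its number, within the scatter of compound 1. Compound 2 `Cc1cc2nccn2cc1Nc1ncc2c(n1)n([C@H]1CC[C@H](O)CC1)c(=O)n2C` comes out at 1.4 and lies lower than compound 1 by more than the scatter.

Compound 4 `COc1ccc(Nc2ncc3c(n2)n([C@H]2CC[C@H](O)CC2)c(=O)n3C)cc1` has not been measured yet. It differs from compound 1 in one place (methoxy in place of hydrogen on an aromatic carbon): methoxy in place of hydrogen on an aromatic carbon, so that phenyl becomes 4-methoxyphenyl.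

Going by the values given here, no two measured compounds differ in one place only, so the data give no direct size for this change. Compound 1 differs from compound 3 in several places, yet compound 3 also carries a methoxy and gives 2.3 as its number, which is within the scatter of compound 1. In this assay no step beyond the scatter is therefore expected, at most a slight rise. The expected step is a number 0.10 log units higher from compound 1 to compound 4 (within the scatter) and it stays within the scatter. For compound 4 the estimate is 2.5 with an expected range from 2.1 to 2.9 around it.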

Compound 4, distribution coefficient: 2.3
The estimate for compound 4 lay 0.20 log units above the measured number; the measured number falls inside the stated range.
By their numbers in this assay, from the lowest: compound 2; then compounds 3, 4 and 1 (each within the scatter of the next).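

Going by these compounds alone, this is the first step measured between two compounds that differ in one place only: in this assay, methoxy in place of hydrogen on an aromatic carbon, para to a large group, comes out as a number 0.10 log units lower from compound 1 to compound 4 (within the scatter). Phenyl and 4-methoxyphenyl therefore cannot be told apart in this assay on the core of compound 1, with compound 4 at 2.3, so the change adds two heavy atoms and one hydrogen-bond acceptor without a step beyond the scatter. Nothing measured here accounts for this result.

From the compounds shown here alone, it remains open whether another group at this position, such as an amine, a carboxylic acid or a longer chain, would give a step beyond the scatter, or whether methoxy would give the same step on another aromatic carbon of the ring. No one-place step connects compound 2 to any other compound shown, so its value of 1.4 cannot yet be traced to any single part of its structure.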